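Imine-linked coumarin series: notes on compound 3

The compounds below may be only part of what the source reports. "The series", "measured", "known", "first", "only" and "open" are said of these compounds alone.

Measured so far:
- compound 1, `CCCCCC/N=C(\C)c1c(O)c2ccccc2oc1=O`: 2900 nM in an assay on isolated protein for inhibition of myosin-2 (Bos taurus), read by spectrophotometry, with a stated time of 24 min; on this read-out lower numbers stand for stronger inhibition and higher numbers for weaker inhibition
- compound 2, `C/C(=N\Cc1cccc(C)c1)c1c(O)c2ccccc2oc1=O`: 4900 nM

Going by the values given here, compound 2 stands alongside compound 1 on the two numbers in hand; the only step between measured compounds, a 1.7-fold higher number from compound 1 to compound 2 (0.23 log units; within the scatter), falls within the scatter, so the two cannot be told apart on this read-out.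

The next compound, compound 3, `C/C(=N\CC(C)C)c1c(O)c2ccccc2oc1=O`, keeps the shared core of compound 2 and alters only the substituent on the imine carbon. The change is isopropyl in place of 3-methylphenyl on a saturated chain carbon bound to a double-bonded nitrogen.

Only one measured step bears on this position, and it is the one from compound 1 to compound 2 described above: swapping the pentyl for a 3-methylphenyl on that saturated chain carbon moved the number by less than the scatter. A further swap to isopropyl at the same place is therefore not expected to produce a step that clears the scatter either; the estimate is a 1.1-fold lower number from compound 2 to compound 3 (0.04 log units; within the scatter).

For compound 3 the expected value in this assay is 4500 nM, with a range from 1800 nM to 12000 nM.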

Compound 3, half-maximal inhibitory concentration: 34000 nM
For compound 3 the middle estimate is 7.6-fold (0.88 log units) below the measured one, and the stated range ends below it.
By their numbers in this assay, from the lowest: compounds 1 and 2 (each within the scatter of the next); then compound 3.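

At this place on a saturated chain carbon bound to a double-bonded nitrogen, the number in this assay does respond to the group carried: isopropyl in place of 3-methylphenyl gives a 6.9-fold higher number from compound 2 to compound 3 (0.84 log units; beyond the scatter), and isopropyl in place of pentyl gives a 12-fold higher number from compound 1 to compound 3 (1.07 log units; beyond the scatter), which the earlier step within the scatter gave no sign of. Loss of the aromatic ring does not on its own account for the separation, since the pentyl of compound 1 carries no ring either and stays within the scatter of the 3-methylphenyl of compound 2, so among these three groups the higher number goes with isopropyl alone. Nothing available here bears on why isopropyl separates from the other two groups.

Going by these compounds alone, with only three groups at this place, it remains open whether the separation follows the branching of isopropyl or the length of the chain, and an unbranched propyl or butyl would fall on one side or the other. Also open, from the compounds shown here alone, is how the number responds to a polar end group on a longer chain, such as an amine or a carboxylic acid.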